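Swapping Chloro for Trifluoromethyl on a Shared Urea Core

This account rests on a few compounds, and the source may have more. Where it says the series, first, only, none or still open, it means among the compounds named here.

Measured compounds:
Compound 1, `COc1ccccc1C(=O)NC(=O)Nc1ccc(N2CCCCC2)c(Cl)c1`, in an in vitro ADME assay on microsomes from liver (Rattus norvegicus) for metabolic stability, with a stated time of 30 min (on this read-out lower numbers stand for slow clearance and higher numbers for fast clearance), gives 36 mL.min-1.g-1.
Compound 2, `COc1ccccc1C(=O)NC(=S)Nc1ccc(N2CCCCC2)c(Cl)c1`, in this assay gives 29 mL.min-1.g-1.
Compound 3, `COc1ccccc1C(=O)NC(=O)Nc1ccc(-c2nccs2)c(C(F)(F)F)c1`, in this assay gives 33 mL.min-1.g-1.

The three compounds share a core built around an aromatic amide joined to a urea or thiourea, and all three show numbers of similar size in this assay. Compound 1 gives the highest of the three numbers, but its gap to compound 3 and its gap to compound 2 both fall within the usual scatter, so no ordering among the three can be claimed from these values.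

Compound 4, `COc1ccccc1C(=O)NC(=O)Nc1ccc(N2CCCCC2)c(C(F)(F)F)c1`, has not yet been measured. It is compound 1 with one change: trifluoromethyl in place of chloro on an aromatic carbon. Among the compounds with values here, compound 3 also carries a trifluoromethyl at that place, although it differs from compound 1 in a second group as well, so no single step between measured compounds separates the two substituents.

Since compound 1 gives 36 mL.min-1.g-1 and compound 3 gives 33 mL.min-1.g-1, the expectation is that the step from compound 1 to compound 4 stays within the scatter, with no clear direction, estimated as a 1.1-fold lower number from compound 1 to compound 4 (0.04 log units; within the scatter). Compound 4 is therefore expected to give 33 mL.min-1.g-1 in this assay, with a range from 17 mL.min-1.g-1 to 66 mL.min-1.g-1.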

Compound 4, intrinsic clearance in microsomes: 26 mL.min-1.g-1
Estimate against measurement, compound 4: 1.3-fold (0.10 log units) above, within the range that was stated.
By their numbers in this assay, from the lowest: compounds 4, 2, 3 and 1 (each within the scatter of the next).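

In this assay, the swap of chloro for trifluoromethyl, on the aromatic carbon ortho to a piperidin-1-yl group, now has a clean step of its own, a 1.4-fold lower number from compound 1 to compound 4 (0.14 log units; within the scatter), with the rest of the molecule held the same. A second single-place comparison keeps the trifluoromethyl and puts piperidin-1-yl in place of 1,3-thiazol-2-yl on an aromatic carbon, giving a 1.3-fold lower number from compound 3 to compound 4 (0.10 log units; within the scatter), so in this small set neither swap separates its pair of compounds beyond the scatter of repeat measurements. No separate measurement of any property of these groups accompanies the clearance numbers.

The compounds shown leave open how a methoxy group or an amine on that same aromatic carbon would read in this assay, and whether trifluoromethyl in place of chloro would also stay within the scatter on the thiourea of compound 2. They also leave open whether a morpholin-4-yl group in place of piperidin-1-yl would give a step large enough to read with confidence.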